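The source may report more compounds than this note shows. Statements on the series, on what has been measured and on what is new or still open speak of the compounds shown alone.

For the measured compounds named here, in a functional assay on L1210 cells (Mus musculus) for cytotoxicity, read by cell counting, with a stated time of 2 days (on this read-out lower numbers stand for stronger inhibition and higher numbers for weaker inhibition), compound 1 `C=C(Br)C(=O)Nc1cccc(/C=C2\SC(=O)N(Cc3ccc(Cl)cc3)C2=O)c1` gives 940 nM, the lowest of the two numbers measured so far. Its nearest neighbour is compound 2 `Nc1cccc(/C=C2\SC(=O)N(Cc3ccc(Cl)cc3)C2=O)c1`, which in this assay gives 218000 nM; the step of a 230-fold higher number from compound 1 to compound 2 (2.37 log units; beyond the scatter) arises from hydrogen in place of (1-bromoethenyl)carbonyl on a nitrogen on an aromatic ring. Compound 3 `C=C(Br)C(=O)Nc1cccc(/C=C2\SC(=O)N(Cc3ccc(C(C)(C)C)cc3)C2=O)c1` keeps that group intact and instead alters the other end of the shared core: tert-butyl in place of chloro on an aromatic carbon. Going by the values given here, no measured step touches this ring carbon, so the one large step recorded does not bear directly on the change, and no guide to its size exists in the data beyond the fact that the group most clearly tied to potency is unchanged. For compound 3 the expected step is a 1.3-fold higher number from compound 1 to compound 3 (0.11 log units; within the scatter), staying within the usual scatter. Compound 3 is therefore estimated at 1200 nM in this assay, with a range from 300 nM to 5000 nM.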

Compound 3, half-maximal inhibitory concentration: 3200 nM
Compound 3: the middle estimate sits 2.7-fold (0.43 log units) below what was measured, within the range that was stated.
By their numbers in this assay, from the lowest: compound 1; then compound 3; then compound 2.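

In this assay, the ring carbon carrying the chloro is not a silent spot: replacing chloro with tert-butyl gives a 3.4-fold higher number from compound 1 to compound 3 (0.53 log units; beyond the scatter), a modest but real step. Even so, swapping a group of 1 heavy atom for one of 4 changes the number far less than removing the (1-bromoethenyl)carbonyl group, which gives a 230-fold higher number from compound 1 to compound 2 (2.37 log units; beyond the scatter). The results offer no explanation for why tert-butyl gives the higher number.

From the compounds shown here alone, with only chloro and tert-butyl at this position, it remains open whether a fluoro, a methoxy, an amine or a carboxylic acid would stay close to compound 1 or move further from it. It is also unclear whether the size of this step would hold if the (1-bromoethenyl)carbonyl group were replaced by another group.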